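A few compounds are considered here, and "the series" means these few. Any claim that something is new, unique, unknown or untested is made for them only; others in the source may bear on it.

Compounds measured so far:

Compound 1, `CO[C@@H]1CC=C2NN(c3ccc(C)cc3)C(=O)C[C@]2(C)O1`, with 25300 nM in a functional assay on SK-N-SH cells (Homo sapiens) for inhibition, read by sulforhodamine B assay, with a stated time of 48 h; a lower number here means a stronger inhibitor, a higher number a weaker inhibitor.
Compound 2, `CO[C@@H]1CC=C2NN(c3cc4ccccc4[nH]3)C(=O)C[C@]2(C)O1`, with 19500 nM.
Compound 3, `CO[C@@H]1CC=C2NN(c3cc4ccccc4[nH]3)C(=O)C[C@]2(c2ccncc2)O1`, with 3900 nM.

Compound 3 gives the lowest number of the three. Its nearest neighbour is compound 2, which stands a 5.0-fold lower number from compound 2 to compound 3 (0.70 log units; beyond the scatter) behind it, and compound 1 lies furthest away. Within the data shown here, the step from compound 2 to compound 3 is the only one in which two compounds differ in one place, and it concerns the pyridin-4-yl group on the saturated ring carbon, not the group on the amide-type nitrogen.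

The next compound, compound 4, is `CO[C@@H]1CC=C2NN(c3cc(Cl)cc(Cl)c3)C(=O)C[C@]2(c2ccncc2)O1`. Its difference from compound 3 is 3,5-dichlorophenyl in place of 1H-indol-2-yl on an amide-type nitrogen in a ring. Among the measured compounds shown here, no measured step bears directly on this change. For the measured compounds named here, compounds 1 and 2, which carry a different group on that nitrogen, show values within the scatter of each other, so the one comparison available at that position gives no movement. On that basis the step of a 1.0-fold higher number from compound 3 to compound 4 (0.01 log units; within the scatter) is expected to stay within or near the scatter, with no clear direction. Compound 4 is therefore estimated at 4000 nM, with a range from 1500 nM to 12000 nM.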

Compound 4, half-maximal inhibitory concentration: 8300 nM
Estimate against measurement, compound 4: 2.1-fold (0.32 log units) below; the range from low to high includes it.
By their numbers in this assay, from the lowest: compound 3; then compound 4; then compounds 2 and 1 (each within the scatter of the next).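

With the pyridin-4-yl group held in place on the saturated ring carbon, the group on the amide-type nitrogen in a ring now shows a measurable effect in this assay: putting 3,5-dichlorophenyl in place of 1H-indol-2-yl gives a 2.1-fold higher number from compound 3 to compound 4 (0.33 log units; beyond the scatter) as a modest step, the first listed step at this position. The change removes the fused five-membered aromatic ring and its hydrogen-bond donor and brings in two chlorine atoms, so several features change at once and this single step cannot separate them. Nothing available explains why the number rises with this change.

The compounds shown leave open whether an unsubstituted phenyl or a phenyl bearing a single chlorine would stand closer to compound 3 or to compound 4, and whether an amine or a carboxylic acid on that ring would move the number in either direction. They also leave open whether 3,5-dichlorophenyl in place of 1H-indol-2-yl would give a similar step with methyl rather than pyridin-4-yl on the saturated ring carbon.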